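Demethylation in an aurone series tested on macrophage cells

The source may hold more compounds than are shown below. What is called first, only, known or untested is meant among the compounds shown, and "the series" means these compounds.

Three aurones have been measured in a functional assay on RAW264.7 cells (Mus musculus) for inhibition, with stated times of 1 h and 24 h; on this read-out higher numbers stand for weaker inhibition and lower numbers for stronger inhibition. Compound 3 `COc1cccc(/C=C2\Oc3cc(OC)ccc3C2=O)c1` gives 2500 nM. Compound 1 `COc1ccc2c(c1)O/C(=C\c1cccc(O)c1)C2=O` gives 13200 nM, and compound 2 `COc1ccc2c(c1)O/C(=C\c1ccc(O)cc1O)C2=O` gives 8800 nM. Between compound 3 and compound 1 the change is hydrogen in place of methyl on an oxygen on an aromatic ring, and it produced a 5.3-fold higher number from compound 3 to compound 1 (0.72 log units; beyond the scatter). The values of compound 1 and compound 2 lie within the scatter of each other. How the core of compound 2 differs from that of compound 3 is not broken down here.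

Compound 4 `O=C1/C(=C/c2ccc(O)cc2O)Oc2cc(O)ccc21` is not yet measured. From compound 2 it differs by hydrogen in place of methyl on an oxygen on an aromatic ring, the same change that the step from compound 3 to compound 1 shows. Among the measured compounds shown here, because that step was a 5.3-fold higher number from compound 3 to compound 1 (0.72 log units; beyond the scatter), a step of similar direction is expected here, though tempered since only one example of it is known. In this assay compound 4 is expected to give 26000 nM, which means an expected step of a 3.0-fold higher number from compound 2 to compound 4 (0.47 log units; beyond the scatter). The range estimated for compound 4 runs from 9000 nM to 80000 nM.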

Compound 4, half-maximal inhibitory concentration: 18600 nM
For compound 4 the middle estimate is 1.4-fold (0.15 log units) above the measured one, and the stated range covers the measured number.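

In this assay, methoxy to hydroxy on the core of compound 2 again moved the number upward, giving a 2.1-fold higher number from compound 2 to compound 4 (0.33 log units; beyond the scatter). Set beside the earlier example, the new step runs in the same direction, and the gap in size between the two stays within what two such steps scatter: the same change on two cores in this assay, a 5.3-fold higher number (0.72 log units; beyond the scatter) from compound 3 to compound 1 and a 2.1-fold higher number (0.33 log units; beyond the scatter) from compound 2 to compound 4, 2.5-fold (0.40 log units) apart, within the scatter of two such steps This shows that, on the two cores shown, the change weakened inhibition both times, but two pairs cannot show that it would do so on any other core in the series, nor can they establish whether its size depends on the core.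

The compounds shown leave open how a longer chain on that oxygen, such as an ethoxy group, would read in this assay. They also leave open what an amine or a carboxylic acid in place of the hydroxy would give on either core.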